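The compounds below may be only part of what the source reports. "The series", "measured", "known", "first", "only" and "open" are said of these compounds alone.

Compound 1, `COc1cc(Br)ccc1Nc1cc(NC(=O)Nc2c(Cl)cccc2Cl)ncn1`, gives 42.7% in a functional assay on HCC827 cells (Homo sapiens) for inhibition, read by MTT assay, with a stated time of 48 h, tested at 10 uM; a higher number here means more inhibition at the concentration tested (going by the name of the read-out), a lower number less inhibition. Among the three measured compounds this is the lowest number: compound 3, `COc1cc(NC(=O)Nc2cc(Nc3ccc(Br)cc3OC)ncn2)cc(OC)c1`, gives 57.7%, and compound 2, `COc1cc(NC(=O)Nc2cc(Nc3cc(C(F)(F)F)ccc3OC)ncn2)cc(OC)c1`, gives 59.7%. Going by the values given here, the only measured single-point step, a number 15 percentage points higher from compound 1 to compound 3 (beyond the scatter), replaces the group on the amide-type nitrogen, not the group on the ring nitrogen.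

Compound 4, `CCc1ccc(Nc2cc(NC(=O)Nc3c(Cl)cccc3Cl)ncn2)cc1`, differs from compound 1 at that ring nitrogen: 4-ethylphenyl in place of 4-bromo-2-methoxyphenyl on a nitrogen on an aromatic ring. Among the compounds with values here, no measured step covers a change at this position. Compounds 2 and 3 differ from each other in the group on the ring nitrogen, yet their two values lie close together, within the usual scatter, which suggests that the ring-nitrogen substituent has had little visible effect so far. The change to compound 4 is larger, removing the bromine and the methoxy group and bringing in an ethyl group, so the outcome is uncertain, but no measured step gives a reason to expect a shift beyond the scatter in either direction. Compound 4 is therefore estimated at 42%, with a range from 25% to 60%, meaning an expected step of a number 0.7 percentage points lower from compound 1 to compound 4 (within the scatter).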

Compound 4, a percentage reported as inhibition, at one concentration (the size of the read-out at that concentration, not a potency): 58%
For compound 4 the middle estimate is 16 percentage points below the measured one; low and high end bracket the measured number.
By their numbers in this assay, from the lowest: compound 1; then compounds 3, 4 and 2 (each within the scatter of the next).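

In this assay, going by these compounds alone, the step of a number 15.3 percentage points higher from compound 1 to compound 4 (beyond the scatter) is the first measured change in the group on the ring nitrogen that lies beyond the scatter, which shows that this position can matter, at least with 2,6-dichlorophenyl on the amide-type nitrogen. The earlier pair with 3,5-dimethoxyphenyl there showed no such separation: compound 2 at 59.7% and compound 3 at 57.7% lie within the scatter of each other, even though their ring-nitrogen groups differ. Because this single swap of 4-bromo-2-methoxyphenyl for 4-ethylphenyl removes the bromine and the methoxy group and adds the ethyl group all at once, it cannot assign the change to any one of them, and no measurement on hand explains it.

The compounds shown leave open which of these three alterations matters, and 4-bromophenyl or 4-ethyl-2-methoxyphenyl on the ring nitrogen would help separate them. They also leave open whether 4-ethylphenyl gives a similar step alongside 3,5-dimethoxyphenyl on the amide-type nitrogen, and how a longer chain such as butyl or an amine such as dimethylamino in place of the ethyl group would read out.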